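Swapping methyl for chloro on the benzoyl ring

The source may report more compounds than this note shows. Statements on the series, on what has been measured and on what is new or still open speak of the compounds shown alone.

Compound 3 `Cc1cccc(C(=O)NCc2ccc(CNS(=O)(=O)c3ccccc3)cc2)c1` shares its core with compound 1 `O=C(NCc1ccc(CNS(=O)(=O)c2ccccc2)cc1)c1ccc([N+](=O)[O-])cc1` and compound 2 `O=C(NCc1ccc(CNS(=O)(=O)c2ccccc2)cc1)c1ccccc1F`. In an assay on MDA-MB-231 cells for binding affinity to C-X-C chemokine receptor type 4 (Homo sapiens), read by immunofluorescence and microscopy, with stated times of 10 min and 30 min (on this read-out lower numbers stand for an effect already at smaller amounts and higher numbers for an effect only at larger amounts of compound), compound 1 gives 100 nM, compound 2 gives 1000 nM, and compound 3 gives 1000 nM, so compound 3 sits level with compound 2 at the highest numbers, with no change at the digits printed from compound 2 to compound 3 (within the scatter), while a 10-fold higher number from compound 1 to compound 3 (1.00 log units; beyond the scatter). Compound 4 `O=C(NCc1ccc(CNS(=O)(=O)c2ccccc2)cc1)c1cccc(Cl)c1` differs from compound 3 by chloro in place of methyl on an aromatic carbon. For the measured compounds named here, no measured step swaps methyl for chloro; the only step that keeps the ring size and shifts a small group, the one from compound 2 to compound 3, stayed within the scatter. Compound 4 is therefore expected to show no change at the digits printed from compound 3 to compound 4 (within the scatter). The estimate for compound 4 is 1000 nM, expected between 300 nM and 3000 nM.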

Compound 4, effective concentration (reported as EC, without a stated level of effect): 1000 nM
Estimate against measurement, compound 4: no gap at the digits printed; the range from low to high includes it.
By their numbers in this assay, from the lowest: compound 1; then compounds 2, 3 and 4 (each within the scatter of the next).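

For the compounds shown here, at the ring place held by methyl in compound 3, chloro gives the same reading in this assay (no change at the digits printed from compound 3 to compound 4 (within the scatter)), the first direct exchange of these two single-atom groups. The 3-chlorophenyl group also matches the 2-fluorophenyl group (no change at the digits printed from compound 2 to compound 4 (within the scatter)), while the 4-nitrophenyl group still stands apart (a 10-fold higher number from compound 1 to compound 4 (1.00 log units; beyond the scatter)). No measurement shown explains why these groups read alike.

Still open is whether the lower number of compound 1 belongs to the nitro group or to its place on the ring, as the compounds shown change both together. Also open, as far as these compounds go, is how an amine or a carboxylic acid would read in place of the chloro.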